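Isomeric chain swap from compound 3 to compound 4

The source may report more compounds than this note shows. Statements on the series, on what has been measured and on what is new or still open speak of the compounds shown alone.

In a functional assay on MCF7 cells (Homo sapiens) for cytotoxicity, read by MTT assay, with a stated time of 3 days (on this read-out lower numbers stand for stronger inhibition and higher numbers for weaker inhibition), compound 3 (`CCC(C)COC(=O)Nc1nc(=O)n([C@@H]2O[C@H](C)[C@H]3OC(=O)O[C@H]32)cc1F`) gives 70 ug/mL and compound 1 (`CCCCCOC(=O)Nc1nc(=O)n([C@@H]2O[C@H](C)[C@H]3OC(=O)O[C@H]32)cc1F`) gives 80 ug/mL with the two level within the scatter. Compound 2 (`C[C@H]1O[C@@H](n2cc(F)c(NC(=O)Oc3ccc([N+](=O)[O-])cc3)nc2=O)[C@@H]2OC(=O)O[C@@H]21`) gives 6 ug/mL and stands apart from both (a 13-fold lower number from compound 1 to compound 2 (1.12 log units; beyond the scatter)) and (a 12-fold higher number from compound 2 to compound 3 (1.07 log units; beyond the scatter)). Compound 4 (`CC(C)CCOC(=O)Nc1nc(=O)n([C@@H]2O[C@H](C)[C@H]3OC(=O)O[C@H]32)cc1F`) differs from compound 3 by isobutyl in place of sec-butyl on a saturated chain carbon bound to an oxygen next to a carbonyl group with isobutyl in place of sec-butyl on a saturated chain carbon bound to an oxygen next to a carbonyl group. The nearest measured change is between two saturated chains (a 1.1-fold lower number from compound 1 to compound 3 (0.06 log units; within the scatter)) and stayed within the scatter. Both large steps involve the 4-nitrophenyl group of compound 2, which plays no part in this change. In this assay no step beyond the scatter is therefore expected. The estimated outcome (no change at the digits printed from compound 3 to compound 4 (within the scatter)) is a number close to the starting one. Compound 4 is estimated at 70 ug/mL with an expected range from 35 ug/mL to 140 ug/mL in this read-out.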

Compound 4, half-maximal inhibitory concentration: 100 ug/mL
The estimate for compound 4 lay 1.4-fold (0.15 log units) below the measured number; low and high end bracket the measured number.
By their numbers in this assay, from the lowest: compound 2; then compounds 3, 1 and 4 (each within the scatter of the next).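

In this assay, moving the branch along the chain leaves the number within the scatter, with isobutyl in place of sec-butyl (a 1.4-fold higher number from compound 3 to compound 4 (0.15 log units; within the scatter)) and isopropyl in place of propyl (a 1.3-fold higher number from compound 1 to compound 4 (0.10 log units; within the scatter)), so the three saturated chains at this place now sit level. The large gap to the aryl carbamate also holds for the new chain, with isopentyl in place of 4-nitrophenyl (a 17-fold higher number from compound 2 to compound 4 (1.22 log units; beyond the scatter)). No available data explain why compound 2 stands apart from these chains.

Still open, going by these compounds, is whether an unsubstituted phenyl or a longer chain such as octyl would read like 4-nitrophenyl or like the saturated chains.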